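Will a Fluorophenyl Group Lift Compound 4 Off the Limit?

The source may report more compounds than this note shows. Statements on the series, on what has been measured and on what is new or still open speak of the compounds shown alone.

Measured in an ADME assay on K562 cells (Homo sapiens) for cytotoxicity, read by MTT assay, with a stated time of 48 h; a lower number here means a stronger inhibitor, a higher number a weaker inhibitor:
- Compound 1 `COc1cc2c(cc1OC)CN(CCn1cc(COc3ccc4ccccc4c3)nn1)CC2`: > 100000 nM
- Compound 2 `COc1cc2c(cc1OC)CN(CCn1cc(COc3ccc(C(C)(C)C)cc3)nn1)CC2`: > 100000 nM
- Compound 3 `COc1cc2c(cc1OC)CN(CCn1cc(COc3ccc(C)cc3C)nn1)CC2`: > 100000 nM

Compound 3 gives > 100000 nM, and this is a limit of the assay, not a number. It has no measured position of its own among the three compounds, since the record shows (the limit of > 100000 nM in this assay, at which 3 of the 3 values shown sit).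

Compound 4 `COc1cc2c(cc1OC)CN(CCn1cc(COc3ccc(F)cc3)nn1)CC2` has not yet been measured. It carries 4-fluorophenyl in place of 2,4-dimethylphenyl on an oxygen on a saturated carbon.

The closest guides are the other swaps of the group at this same place. These are a step that the two limits leave unreadable from compound 1 to compound 3, a step that the two limits leave unreadable from compound 2 to compound 3 and a step that the two limits leave unreadable from compound 1 to compound 2. None of them has a size that can be read, so none offers a number to carry over to the new swap. Three different groups here have so far all ended at the same limit, and three compounds are a small sample. The expectation is therefore no real change in this assay, and most likely another limit rather than a number. The estimated step is a number no higher from compound 3 to compound 4 (the limit leaves the size open). For compound 4 the expected value is 100000 nM, with an estimated range from 50000 nM to 200000 nM.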

Compound 4, half-maximal inhibitory concentration: > 100000 nM
Compound 4: a limit, no number; the forecaster's own chance of this, stated with the estimate: 85%; the middle value sits exactly at the limit.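

In this assay compound 4 gives > 100000 nM, which is a limit of the assay and not a number. The steps to compound 4 from compound 1, compound 2 and compound 3 cannot be read, because all four compounds end at the same limit: the limit of > 100000 nM in this assay, at which 4 of the 4 values shown sit. The compounds shown leave open whether changing the group on the oxygen alters cytotoxicity at all, since none gives a number.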